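A few compounds are considered here, and "the series" means these few. Any claim that something is new, unique, unknown or untested is made for them only; others in the source may bear on it.

Among the compounds with values here, compound 2 `Cc1cc2c(cc1Cc1ccc(C(=O)NCC3CCC(CNCc4c(C)noc4C)CC3)o1)C(C)(C)CCC2(C)C` is the weaker of the two compounds measured so far: in an assay on isolated protein for binding affinity to Gonadotropin-releasing hormone receptor (Homo sapiens) (a lower number here means a stronger inhibitor, a higher number a weaker inhibitor), compound 2 gives 180 nM. Within the data shown here, its only neighbour, compound 1 `Cc1cc2c(cc1Cc1ccc(C(=O)NCC3CCC(CNC(=O)C(F)(F)F)CC3)o1)C(C)(C)CCC2(C)C`, gives 66 nM in this assay, so compound 2 stands at the top of the two numbers. Among the measured compounds shown here, the single measured step, a 2.7-fold higher number from compound 1 to compound 2 (0.44 log units; beyond the scatter), shows that swapping the group carried on the amine nitrogen moves the number by a modest amount.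

Compound 3 `Cc1cc2c(cc1Cc1ccc(C(=O)NCC3CCC(CNCc4cc(O)nc(O)n4)CC3)o1)C(C)(C)CCC2(C)C` keeps the shared core and the amine, and differs from compound 2 only in the group on the saturated chain carbon bound to that nitrogen: 2,6-dihydroxypyrimidin-4-yl in place of 3,5-dimethyl-1,2-oxazol-4-yl on a saturated chain carbon bound to an amine nitrogen. For the measured compounds named here, no measured pair covers this particular swap. The step from compound 1 to compound 2 is the only one that bears on it, and it says that changing this group can shift this assay by a modest step in either direction. The expected result for compound 3 is therefore a step of about a 1.2-fold higher number from compound 2 to compound 3 (0.09 log units; within the scatter), with little confidence in its direction. Compound 3 is estimated at 220 nM, within a range from 60 nM to 800 nM.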

Compound 3, inhibition constant: 24 nM
For compound 3 the middle estimate is 9.2-fold (0.96 log units) above the measured one, outside the stated range (below it).
By their numbers in this assay, from the lowest: compound 3; then compound 1; then compound 2.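

In this assay, the group on a saturated chain carbon bound to an amine nitrogen proves able to move the number in the favourable direction: 2,6-dihydroxypyrimidin-4-yl in place of 3,5-dimethyl-1,2-oxazol-4-yl gives a step (a 7.5-fold lower number from compound 2 to compound 3 (0.88 log units; beyond the scatter)) larger than the only earlier one (a 2.7-fold higher number from compound 1 to compound 2 (0.44 log units; beyond the scatter)). The (2,6-dihydroxypyrimidin-4-yl)methyl group also outdoes the (trifluoromethyl)carbonyl group on the amine nitrogen (a 2.8-fold lower number from compound 1 to compound 3 (0.44 log units; beyond the scatter)), so an amine bearing the right aromatic ring can do better than the trifluoroacetyl amide, and compound 3 has the lowest number of the three. Nothing available accounts for either shift.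

The change alters the ring size, the ring atoms and the hydroxy groups all at once, so these compounds cannot show which of these differences matters. A plain phenyl ring, or a pyrimidin-4-yl ring with one hydroxy group or none, would be needed on this carbon to pull those differences apart.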